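This account rests on a few compounds, and the source may have more. Where it says the series, first, only, none or still open, it means among the compounds named here.

Series notes. Three compounds share one core; compound 1 `CCCCOC(=O)CC1c2cccc(C)c2S(=O)(=O)N1C(=O)OC` and compound 2 `CCCCOC(=O)CC1c2cccc(C)c2S(=O)(=O)N1C(=O)/C=C/c1ccc(Cl)cc1` differ from compound 3 `CCCCOC(=O)CC1c2cccc(C)c2S(=O)(=O)N1C(=O)c1cccc(C(F)(F)F)c1` elsewhere in the molecule, not in the butyl ester side chain. In an assay on HEK-Blue hNOD1 cells for antagonist activity at Nucleotide-binding oligomerization domain-containing protein 1 (Homo sapiens), read by reporter gene assay, with stated times of 3 h and 20 h (on this read-out lower numbers stand for stronger inhibition and higher numbers for weaker inhibition), compound 1 gives "not determined" (no result reported). In this assay compound 2 gives "not determined" (no result reported). In this assay compound 3 gives 1050 nM. Among the measured compounds shown here, compound 3 therefore stands as the only number in the set; with no second measured value, no step between measured compounds can be drawn, and nothing here shows how sensitive the read-out is to the side chain.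

Compound 4 `CCCCc1nnc(CC2c3cccc(C)c3S(=O)(=O)N2C(=O)c2cccc(C(F)(F)F)c2)o1` keeps the whole of compound 3 apart from the change 5-butyl-1,3,4-oxadiazol-2-yl in place of butoxycarbonyl on a saturated chain carbon bound to a saturated ring carbon: the ester gives way to a five-membered aromatic ring with three hetero atoms and one more hydrogen-bond acceptor, the butyl chain being retained on the new ring. For the measured compounds named here, with no measured step to rest on, the expectation is a step within or close to the usual scatter, tilted slightly toward stronger inhibition, so that the estimated step from compound 3 to compound 4 is a 1.3-fold lower number from compound 3 to compound 4 (0.12 log units; within the scatter). Compound 4 is thus expected to give about 800 nM in this assay, with a range from 300 nM to 2500 nM.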

Compound 4, half-maximal inhibitory concentration: 1740 nM
Beside the measured number, compound 4's estimate is 2.2-fold (0.34 log units) below it, and the stated range covers the measured number.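

Working notes on the side chain: the series now has its first measured step. In this assay, 5-butyl-1,3,4-oxadiazol-2-yl in place of butoxycarbonyl on a saturated chain carbon bound to a saturated ring carbon gives a 1.7-fold higher number from compound 3 to compound 4 (0.22 log units; within the scatter), so within this one pair the ester is not needed to keep a measurable read-out. Among the compounds shown here, the position therefore accepts a five-membered aromatic ring with 3 hetero atoms that retains the butyl chain, with no step that can be told from the scatter. No measurement at hand on either group bears on this result.

Open, from the compounds shown here alone, is how the read-out responds to a carboxylic acid or an amine on the same chain carbon, and to a methyl group or a longer chain such as octyl in place of the butyl chain on the new ring; one step within the scatter does not settle how sensitive this position is. Compound 1 gives "not determined" (no result reported) and compound 2 gives "not determined" (no result reported), so the part of the molecule in which they differ from compound 3 remains without any comparison.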